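The source may report more compounds than this note shows. Statements on the series, on what has been measured and on what is new or still open speak of the compounds shown alone.

Compound 2 `CCOC(=O)CCCCCOc1cccc(CN(C(=O)c2ccc(-c3cc(OC)ccc3F)cc2)C(C)C)c1` carries a 2-fluoro-5-methoxyphenyl group on the shared core. In an ADME assay on HepG2 cells (Homo sapiens) for cytotoxicity, read by CellTiter-Glo and resazurin assay, with a stated time of 72 h (a lower number here means that less compound is needed, a higher number that more compound is needed for the effect), compound 2 gives > 26000 nM, which is a limit of the assay rather than a number. Compound 2 thus sits at the limit of > 26000 nM in this assay, at which 1 of the 2 values shown sits. Compound 1 `CCOC(=O)CCCCCOc1cccc(CN(C(=O)c2ccc(-c3cccc(OC)c3)cc2)C(C)C)c1` has a hydrogen where compound 2 has the fluorine. In this assay compound 1 gives > 21000 nM, again a limit of the assay. Compound 1 thus sits at the limit of > 21000 nM in this assay, at which 1 of the 2 values shown sits. The step that the two limits leave unreadable from compound 1 to compound 2 cannot be read in size. Compound 3 `CCOC(=O)CCCCCOc1cccc(CN(C(=O)c2ccc(-c3ccc(Cl)c(Cl)c3)cc2)C(C)C)c1` is not yet measured; it differs from compound 2 by 3,4-dichlorophenyl in place of 2-fluoro-5-methoxyphenyl on an aromatic carbon. Among the compounds with values here, no measured step bears directly on this change, and the single measured step is unreadable, so the only guide is that neither measured compound reached a readable effect. For compound 3 the expected step of an at least 1.0-fold lower number from compound 2 to compound 3 (0.01 log units; that floor lies within the scatter) is none beyond the scatter. Compound 3 is estimated at 25000 nM, with a range from 8000 nM to 60000 nM, and most likely only a limit will be reported again.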

Compound 3, half-maximal effective concentration: > 26000 nM
Compound 3: a limit, no number (the forecaster's own chance of this, stated with the estimate: 70%); middle value at least 1.0-fold (0.01 log units) from the limit.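

Compound 3, like compound 1 and compound 2, gives only a limit in this assay, so the steps among these three compounds cannot be read in size. The compounds shown leave open at what concentration, if any, each would reach the half-maximal effect.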